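This account rests on a few compounds, and the source may have more. Where it says the series, first, only, none or still open, it means among the compounds named here.

Measured compounds in a functional assay on MIA PaCa-2 cells (Homo sapiens) for inhibition, read by MTT assay, with a stated time of 3 days; on this read-out lower numbers stand for stronger inhibition and higher numbers for weaker inhibition:
compound 1, `CC(C)c1noc(N2CCN(C(=O)[C@@H]3CCCN(S(=O)(=O)c4ccc(S(=O)(=O)C(C)C)cc4)C3)CC2)n1`: > 10000 nM
compound 2, `CCN(CC)C(=O)[C@@H]1CCCN(S(=O)(=O)c2ccc(S(=O)(=O)N(CC)CC)cc2)C1`: > 10000 nM
compound 3, `CCN1CC(NC(=O)[C@@H]2CCCN(S(=O)(=O)c3ccc(S(=O)(=O)N(CC)CC)cc3)C2)C1`: > 10000 nM

In this assay compound 1 gives > 10000 nM, which is a limit of the assay and not a number. Compound 2 likewise gives > 10000 nM, again a limit. Compound 3 gives > 10000 nM, also a limit. Within the data shown here, every value shown therefore rests at the limit of > 10000 nM in this assay, at which 3 of the 3 values shown sit, and the single step between measured compounds, a step that the two limits leave unreadable from compound 2 to compound 3, is one the two limits leave unreadable, so its size is unknown.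

Compound 4, `CCNS(=O)(=O)c1ccc(S(=O)(=O)N2CCC[C@@H](C(=O)N3CCN(c4nc(C(C)C)no4)CC3)C2)cc1`, differs from compound 1 by ethylamino in place of isopropyl on a sulfonyl sulfur. No measured step touches a sulfonyl sulfur, so nothing shown speaks directly to this change; the only guidance is that compound 1 itself sits at the limit. Compound 4 is therefore expected to stay near that limit, with an estimated value of 20000 nM and a range from 5000 nM to 100000 nM. The expected step that the limit leaves unreadable from compound 1 to compound 4 amounts to no change read beyond the scatter, with a high chance that only a limit is reported again.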

Compound 4, half-maximal inhibitory concentration: > 10000 nM
Compound 4 gave a limit, no number (the forecaster's own chance of this, stated with the estimate: 80%); the middle value is on the limit's open side.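

Among these compounds, compound 1 and compound 4 both give a limit and not a number in this assay, so no step between them can be read: the limit of > 10000 nM in this assay, at which 4 of the 4 values shown sit.

The compounds shown leave open how far each lies past that limit, and whether any change to the shared core would give a measurable value.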